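The source may report more compounds than this note shows. Statements on the series, on what has been measured and on what is new or still open speak of the compounds shown alone.

In a functional assay on HCC 2998 cells (Homo sapiens) for inhibition, read by sulforhodamine B assay, with a stated time of 48 h (a lower number here means a stronger inhibitor of growth, a higher number a weaker inhibitor of growth), compound 1 (`O=C(Cc1csc2nc(-c3ccc(Br)cc3)cn12)N/N=C/c1ccccc1`) gives 49000 nM as its concentration for total growth inhibition, and compound 2 (`COc1cccc(OC)c1/C=N/NC(=O)Cc1csc2nc(-c3ccc(Br)cc3)cn12`) gives 34700 nM on the same read-out. Among the measured compounds shown here, compound 2 therefore stands level, within the scatter, with compound 1, the only other compound measured so far. Compound 3 (`O=C(Cc1csc2nc(-c3ccc(Br)cc3)cn12)N/N=C/c1ccc(Cl)cc1Cl`) keeps the core of compound 2 but carries 2,4-dichlorophenyl in place of 2,6-dimethoxyphenyl on a carbon with a double bond to nitrogen. For the measured compounds named here, only one measured step bears on this place: replacing phenyl with 2,6-dimethoxyphenyl gave a 1.4-fold lower number from compound 1 to compound 2 (0.15 log units; within the scatter) and so stayed within the scatter. Going by the values given here, no measured compound carries 2,4-dichlorophenyl, so the data offer no direct reading of that group. Among the compounds with values here, with compound 2 at 34700 nM as the starting point and a 1.4-fold lower number from compound 1 to compound 2 (0.15 log units; within the scatter) as the sole precedent, no change beyond the scatter is expected in this assay for this replacement. The estimated change is a 1.2-fold lower number from compound 2 to compound 3 (0.06 log units; within the scatter) and would be too small to separate the two compounds. Compound 3 is estimated at 30000 nM with an expected range from 11000 nM to 70000 nM on this read-out.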

Compound 3, concentration for total growth inhibition: 44700 nM
Compound 3: middle estimate off by 1.5-fold (0.17 log units), on the low side, and the stated range covers the measured number.
By their numbers in this assay, from the lowest: compounds 2, 3 and 1 (each within the scatter of the next).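

In this assay, at the position on a carbon with a double bond to nitrogen, the change to 2,4-dichlorophenyl gives a 1.3-fold higher number from compound 2 to compound 3 (0.11 log units; within the scatter) and, measured against phenyl, a 1.1-fold lower number from compound 1 to compound 3 (0.04 log units; within the scatter), so all three groups now stand level within the scatter. The earlier pair had tested only one replacement of phenyl, 2,6-dimethoxyphenyl, which brings oxygen and 2 hydrogen-bond acceptors. Compound 3 extends the finding to a group that brings chlorine and 0 hydrogen-bond acceptors, so two quite different sets of atoms on the same aromatic ring have now left this read-out without a change beyond the scatter, and no separate measurement bears on why this is so.

What the compounds shown leave open is whether anything placed here can move the number beyond the scatter, for example an amine or a carboxylic acid on the aromatic ring, or a longer chain in place of that ring. They also leave open whether this level reading would hold if the shared core were altered, since all three compounds keep it unchanged.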